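This account rests on a few compounds, and the source may have more. Where it says the series, first, only, none or still open, it means among the compounds named here.

Compound 2 `Nc1ccccc1NC(=O)c1ccc(Cn2cnc3c(Nc4ccccc4)nc(Cl)nc32)cc1` gives 77.8% in a functional assay on NCI-H460 cells (Homo sapiens) for antiproliferative activity, read by CCK-8 assay, with a stated time of 72 h, tested at 8 uM (a higher number here means a stronger effect of the compound at the concentration tested, a lower number a weaker effect), the highest of the three measured numbers; compound 3 `COC(CCn1cnc2c(NCc3ccc(C(=O)Nc4ccccc4N)cc3)nc(Cl)nc21)OC` gives 51.2%, and compound 1 `Nc1ccccc1NC(=O)/C=C/c1ccc(Cn2cnc3c(Nc4ccccc4)nc(Cl)nc32)cc1` gives 28.7%. Among the compounds with values here, the one single-point step, a number 49.1 percentage points higher from compound 1 to compound 2 (beyond the scatter), concerns the linker to the aminophenyl amide, not the core amine. Compound 4 `CC1CCN(c2nc(Cl)nc3c2ncn3Cc2ccc(C(=O)Nc3ccccc3N)cc2)CC1` differs from compound 2 by 4-methylpiperidin-1-yl in place of anilino on an aromatic carbon. Within the data shown here, no measured step touches this position, so no direction can be read from the data. Compound 4 is therefore expected to give 60%, in a range from 30% to 85%. The expected step from compound 2 is a number 17.8 percentage points lower from compound 2 to compound 4 (beyond the scatter), a modest decrease reflecting uncertainty rather than any shown trend.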

Compound 4, a percentage reported as inhibition, at one concentration (the size of the read-out at that concentration, not a potency): 40.9%
Compound 4: the middle estimate sits 19.1 percentage points above what was measured; measured number inside the range.
By their numbers in this assay, from the lowest: compound 1; then compound 4; then compound 3; then compound 2.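

At this aromatic carbon, this assay shows a number 36.9 percentage points lower from compound 2 to compound 4 (beyond the scatter) when 4-methylpiperidin-1-yl replaces anilino, so this position, untouched by the earlier step, clearly affects the read-out. The two groups match in heavy atoms, but the entering group has no hydrogen-bond donor and no aromatic ring. No measured evidence explains the drop.

On these data alone, whether the lost donor or the lost aromatic ring matters more stays open. A cyclohexylamino group, with its amine hydrogen on a non-aromatic ring, would separate the two, while plain piperidin-1-yl would test the methyl.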